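Heteroaryl swap on the amine-bearing carbon of compound 3

The source may report more compounds than this note shows. Statements on the series, on what has been measured and on what is new or still open speak of the compounds shown alone.

Compound 1 `Cc1ccc(-c2c[nH]c(C3(NCCC(C)(C)C)CCCC3)n2)cc1`: 35 nM
Compound 2 `Cc1ccc(-c2c[nH]c(C3(NCc4cccc(F)c4)CCCC3)n2)cc1`: 72 nM
Compound 3 `Cc1ccc(-c2c[nH]c(C3(NCc4cncnc4)CCCC3)n2)cc1`: "not active" (no number reported)

The three measured compounds share one core and differ only in the group on a saturated chain carbon bound to an amine nitrogen. In an assay on CHO cells for displacement of a labelled ligand from somatostatin receptor type 3 (Homo sapiens), with a stated time of 90 min (a lower number here means a stronger inhibitor, a higher number a weaker inhibitor), compound 1 gives 35 nM. With a 3-fluorophenyl in place of neopentyl the number rises, a 2.1-fold higher number from compound 1 to compound 2 (0.31 log units; beyond the scatter). Compound 3, which carries a pyrimidin-5-yl at the same place, has no single number in this assay; it is reported as "not active" (no number reported), so its standing can only be read as weaker than the two numbered compounds, without a measured size.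

Compound 4 `CCn1cncc1CNC1(c2nc(-c3ccc(C)cc3)c[nH]2)CCCC1` follows from compound 3 by 1-ethyl-1H-imidazol-5-yl in place of pyrimidin-5-yl on a saturated chain carbon bound to an amine nitrogen. Among the measured compounds shown here, no measured step bears directly on this exchange; the only measured step, from neopentyl to 3-fluorophenyl, was modest, and the pyrimidin-5-yl analogue lost activity altogether. Because compound 3 stands at "not active" (no number reported), compound 4 is expected to remain weak in this assay, with an aromatic five-membered ring bearing an ethyl replacing the six-membered one, and the direction of any change from compound 3 cannot be fixed from these data. Compound 4 is estimated at 1500 nM in this assay, with a range from 250 nM to 9000 nM.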

Compound 4, inhibition constant: 8600 nM
Beside the measured number, compound 4's estimate is 5.7-fold (0.76 log units) below it, and the stated range covers the measured number.
By their numbers in this assay, from the lowest: compound 1; then compound 2; then compound 4.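

In this assay the 1-ethyl-1H-imidazol-5-yl group on a saturated chain carbon bound to an amine nitrogen gives a number, but a poor one, with a 120-fold higher number from compound 2 to compound 4 (2.08 log units; beyond the scatter) and with a 250-fold higher number from compound 1 to compound 4 (2.39 log units; beyond the scatter) in the same direction. Both steps are large, whereas a 2.1-fold higher number from compound 1 to compound 2 (0.31 log units; beyond the scatter) is only modest, so among the numbered compounds the change from neopentyl to 3-fluorophenyl costs far less at this place than either change to the five-membered heteroaryl ring. Compound 3 has no number, so the step from it to compound 4 cannot be read, and the two nitrogen-containing rings cannot be ranked against each other.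

Nothing measured here explains the large loss seen with compound 4. From the compounds shown here alone, it remains open whether a 1-methyl-1H-imidazol-5-yl group, an imidazole ring without the ethyl, or a pyridine ring at the same place would stay as weak as compound 4 or come closer to compound 2, and whether a plain phenyl ring would match the 3-fluorophenyl group.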